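Replacing the Side Chain of Compound 2

The source may hold more compounds than are shown below. What is called first, only, known or untested is meant among the compounds shown, and "the series" means these compounds.

In an ADME assay on L6 cells (Rattus norvegicus) for cytotoxicity, read by resazurin assay, with a stated time of 72 h (on this read-out higher numbers stand for weaker inhibition and lower numbers for stronger inhibition), compound 1 (`CN1CCN(CC(=O)N2CC3C(c4ccccc4)CC(N(C)C)(CC3c3ccccc3)C2)CC1`) gives 9250 nM and compound 2 (`CN1CCN(CCC(=O)N2CC3C(c4ccccc4)CC(N(C)C)(CC3c3ccccc3)C2)CC1`) gives 13000 nM, so compound 2 stands level with compound 1. Within the data shown here, the only measured step, a 1.4-fold higher number from compound 1 to compound 2 (0.15 log units; within the scatter), lies within the scatter and keeps the carbonyl, so it bears only weakly on compound 3 (`CN(C)C12CC(c3ccccc3)C(CN(CCN3CCCC3)C1)C(c1ccccc1)C2`). There, (2-(pyrrolidin-1-yl)ethyl in place of (2-(4-methylpiperazin-1-yl)ethyl)carbonyl on an amine nitrogen in a ring), with 2-(pyrrolidin-1-yl)ethyl in place of (2-(4-methylpiperazin-1-yl)ethyl)carbonyl on an amine nitrogen in a ring. Among the measured compounds shown here, no measured step removes the carbonyl, so a tentative move to a lower number in this assay is expected, with the estimated step being a 2.2-fold lower number from compound 2 to compound 3 (0.34 log units; beyond the scatter). Compound 3 is estimated at 6000 nM, with a range of 2000 nM to 18000 nM.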

Compound 3, half-maximal inhibitory concentration: 5580 nM
The estimate for compound 3 lay 1.1-fold (0.03 log units) above the measured number, within the range that was stated.
By their numbers in this assay, from the lowest: compounds 3, 1 and 2 (each within the scatter of the next, the first and the last beyond it).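

In this assay, among these compounds, putting 2-(pyrrolidin-1-yl)ethyl in place of (2-(4-methylpiperazin-1-yl)ethyl)carbonyl on the amine nitrogen in a ring gives a 2.3-fold lower number from compound 2 to compound 3 (0.37 log units; beyond the scatter), the first step in this short series beyond the scatter and the first to remove the carbonyl. Starting from ((4-methylpiperazin-1-yl)methyl)carbonyl instead, the change gives a 1.7-fold lower number from compound 1 to compound 3 (0.22 log units; within the scatter), which stays within the scatter, so the shift is small and not seen from both starting points. No evidence is available to explain either step.

On these data alone, each step changes the carbonyl and the ring together, so it stays open which of them carries the difference. A 2-(4-methylpiperazin-1-yl)ethyl or 2-(morpholin-4-yl)ethyl group on this nitrogen would bear on that question.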